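Hydantoin-type substituent series: toward compound 4

The source may report more compounds than this note shows. Statements on the series, on what has been measured and on what is new or still open speak of the compounds shown alone.

Measured so far in a functional assay on CHO cells for antagonist activity at prostaglandin E2 receptor EP3 subtype (Homo sapiens), read by FLIPR, with a stated time of 1 h; on this read-out higher numbers stand for weaker inhibition and lower numbers for stronger inhibition: compound 1 `CC1(c2ccc(-c3ccc4ccccc4c3)[nH]c2=O)OC(=O)NC1=O` gives 20 nM; compound 2 `O=C1NC(=O)C(c2ccc(-c3ccc4ccccc4c3)[nH]c2=O)(C2CC2)O1` gives 50.1 nM; compound 3 `O=C1NC(=O)C(c2ccc(-c3ccc4ccccc4c3)[nH]c2=O)(C(F)(F)F)O1` gives 126 nM.

Compound 3 sits at the weak end of the three: a 6.3-fold higher number from compound 1 to compound 3 (0.80 log units; beyond the scatter) and a 2.5-fold higher number from compound 2 to compound 3 (0.40 log units; beyond the scatter), both beyond the scatter. Compound 4 `O=C1NC(=O)C(c2ccc(-c3ccc4ccccc4c3)[nH]c2=O)(C2CCOCC2)O1` differs from compound 3 by oxan-4-yl in place of trifluoromethyl on a saturated ring carbon. Among the compounds with values here, the steps that bear on this change are the ring-bearing move a 2.5-fold higher number from compound 1 to compound 2 (0.40 log units; beyond the scatter) and the move to trifluoromethyl a 2.5-fold higher number from compound 2 to compound 3 (0.40 log units; beyond the scatter); replacing trifluoromethyl by a saturated ring is therefore expected to bring the number back toward that of compound 2, giving a small step in this assay, downward or none beyond the scatter. For compound 4 the expected step is a 1.8-fold lower number from compound 3 to compound 4 (0.26 log units; within the scatter), and the estimate is 70 nM with a range of 20 nM to 250 nM.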

Compound 4, inhibition constant: 200 nM
Estimate against measurement, compound 4: 2.9-fold (0.46 log units) below; low and high end bracket the measured number.
By their numbers in this assay, from the lowest: compound 1; then compound 2; then compounds 3 and 4 (each within the scatter of the next).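

At this saturated ring carbon, oxan-4-yl and trifluoromethyl are not told apart in this assay, with a 1.6-fold higher number from compound 3 to compound 4 (0.20 log units; within the scatter), so a six-membered ring does not recover the number of the cyclopropyl compound. That ring carries a real cost against the smaller groups, with a 4.0-fold higher number from compound 2 to compound 4 (0.60 log units; beyond the scatter) and a 10-fold higher number from compound 1 to compound 4 (1.00 log units; beyond the scatter), the latter the largest step in the set. Nothing at hand gives a reason for these steps.

Open, on these data alone, is whether the ring oxygen matters, which cyclohexyl would test. Also open, as far as these compounds go, is how an amine or a longer chain at this carbon would compare with methyl.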